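The source may report more compounds than this note shows. Statements on the series, on what has been measured and on what is new or still open speak of the compounds shown alone.

Measured so far in a functional assay on the whole organism for inhibition, with Rattus norvegicus as the target, read by paw edema; a higher number here means that more compound is needed for the effect, a lower number that less compound is needed:
Compound 1 `O=C(O)c1cc(-c2cc[nH]n2)ccc1O`: compound 1 gives > 250 mg/kg, a limit of the assay rather than a number.
Compound 2 `O=C(O)c1cc(-c2ccno2)ccc1O`: compound 2 gives 110 mg/kg.

Compound 2 thus holds the only number shown; the other value is a limit. Compound 3 `O=C(O)c1cc(-n2cccn2)ccc1O` differs from it by 1H-pyrazol-1-yl in place of 1,2-oxazol-5-yl on an aromatic carbon. Going by the values given here, one measured step bears on this, an at least 2.2-fold lower number from compound 1 to compound 2 (0.35 log units; beyond the scatter), which also exchanged one five-membered ring for another at the same place; since compound 1 sits at the limit of > 250 mg/kg in this assay, at which 1 of the 2 values shown sits, its full size is unknown. Ring identity clearly matters, but no direction follows, so compound 3 is expected near 150 mg/kg, between 60 mg/kg and 300 mg/kg. That expectation amounts to a 1.4-fold higher number from compound 2 to compound 3 (0.13 log units; within the scatter).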

Compound 3, dose for half-maximal effect: 200 mg/kg
Beside the measured number, compound 3's estimate is 1.3-fold (0.12 log units) below it; measured number inside the range.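

In this assay, placing 1H-pyrazol-1-yl where 1,2-oxazol-5-yl stood gives a 1.8-fold higher number from compound 2 to compound 3 (0.26 log units; within the scatter), so these two five-membered aromatic rings cannot be told apart at this position. Compound 1 gives > 250 mg/kg, a limit of the assay and not a number. The other new step, an at least 1.2-fold lower number from compound 1 to compound 3 (0.09 log units; that floor lies within the scatter), offers only a floor, so its true size cannot be read.

Going by these compounds, what remains open is whether this position needs a five-membered ring at all. A phenyl ring, an amine or a longer chain here could give a different answer.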